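A Methyl Group on the Phenyl Ring of a Thiourea Analogue

The source may report more compounds than this note shows. Statements on the series, on what has been measured and on what is new or still open speak of the compounds shown alone.

Of the compounds shown here, two of a shared core have been measured in a functional assay, with a stated time of 20 min, tested at 20 uM; on this read-out higher numbers stand for a stronger effect at the one concentration tested and lower numbers for a weaker effect. Compound 1, `COc1cc(/C=C/C(=O)C2=C(/C=C/c3ccc(O)c(OC)c3)NC(=O)NC2c2cccc([N+](=O)[O-])c2)ccc1O`, gives 66.3% in this assay. Compound 2, `COc1cc(/C=C/C(=O)C2=C(/C=C/c3ccc(O)c(OC)c3)NC(=S)NC2c2ccccc2)ccc1O`, gives 38% in this assay, the lower of the two numbers; compound 1 stands higher by a gap beyond the usual scatter. Going by the values given here, no pair of measured compounds differs in a single place, so no step is available to set a scale for small changes. Compound 3, `COc1cc(/C=C/C(=O)C2=C(/C=C/c3ccc(O)c(OC)c3)NC(=S)NC2c2ccc(C)cc2)ccc1O`, has not yet been measured. It differs from compound 2 as follows: methyl in place of hydrogen on an aromatic carbon. With nothing measured on a change of this kind, compound 3 is expected to remain close to compound 2 in this assay. The expected step of a number 2 percentage points higher from compound 2 to compound 3 (within the scatter) lies within the scatter. For compound 3 the estimate in this assay is 40%, within a range from 25% to 58%.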

Compound 3, a percentage reported as activity, at one concentration (the size of the read-out at that concentration, not a potency): 51%
Compound 3: middle estimate off by 11 percentage points, on the low side; the measured number falls inside the stated range.
By their numbers in this assay, from the lowest: compound 2; then compound 3; then compound 1.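

The change from phenyl to 4-methylphenyl gives a number 13 percentage points higher from compound 2 to compound 3 (beyond the scatter) in this assay. Going by these compounds alone, this is the first step that isolates a single place, and it shows that the read-out responds to one added carbon on the aromatic ring, at the position para to a large group. Nothing available accounts for the rise, so the step stands as an observation without an explanation.

The compounds shown leave open whether the rise is specific to methyl or would also appear with an ethyl chain, a methoxy group or a chlorine atom at this position. They also leave open whether methyl would have a similar effect at another carbon of the ring, or on a core carrying a carbonyl in place of the thiocarbonyl.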